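The compounds below may be only part of what the source reports. "The series", "measured", "known", "first", "only" and "open" are said of these compounds alone.

Compound 2 `c1csc(C2=NNC(c3ccc(N4CCCCC4)cc3)C2)c1` is the reference point here. Among the compounds with values here, in an ADME assay on CCRF-CEM cells (Homo sapiens) for cytotoxicity, with a stated time of 5 days (a higher number here means a weaker inhibitor, a lower number a stronger inhibitor), compound 2 gives 6900 nM, the lowest of the three numbers so far. Its nearest neighbour is compound 3 `Clc1ccsc1C1=NNC(c2ccc(N3CCCCC3)cc2)C1`, which in this assay gives 10200 nM; the step of a 1.5-fold higher number from compound 2 to compound 3 (0.17 log units; within the scatter) stays within the scatter, so the two cannot be told apart. Compound 1 `O=C(/C=C/c1ccc(N2CCCCC2)cc1)c1ccc(Cl)s1`, built on an open chain rather than the shared core, gives in this assay a value of 41500 nM, well beyond the scatter from compound 2.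

The new compound 4 `Ic1ccc(C2=NNC(c3ccc(N4CCCCC4)cc3)C2)s1` differs from compound 2 by one change: iodo in place of hydrogen on an aromatic carbon. Within the data shown here, only one measured step informs this halogen-for-hydrogen exchange on the same five-membered ring, namely a 1.5-fold higher number from compound 2 to compound 3 (0.17 log units; within the scatter), and it was too small to count. On that basis no step beyond the scatter is expected for compound 4, with at most a slight drift to a higher number, so the expected step is a 1.2-fold higher number from compound 2 to compound 4 (0.09 log units; within the scatter). Compound 4 is therefore estimated in this assay at 8500 nM, with a range from 3000 nM to 24000 nM.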

Compound 4, half-maximal inhibitory concentration: 36500 nM
Compound 4: the middle estimate sits 4.3-fold (0.63 log units) below what was measured; the measured number lies above the stated range.
By their numbers in this assay, from the lowest: compounds 2 and 3 (each within the scatter of the next); then compounds 4 and 1 (each within the scatter of the next).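

In this assay, the change from thiophen-2-yl to 5-iodothiophen-2-yl gives a 5.3-fold higher number from compound 2 to compound 4 (0.72 log units; beyond the scatter), so a single iodo at this place, next to the ring sulfur, moves the number beyond the scatter, whereas the chloro step a 1.5-fold higher number from compound 2 to compound 3 (0.17 log units; within the scatter) stayed within it. The two halogen-bearing compounds also separate, with a 3.6-fold higher number from compound 3 to compound 4 (0.55 log units; beyond the scatter), so a halogen on this ring does not have one uniform outcome across these compounds. Nothing available here accounts for the shift.

Compound 3 and compound 4 differ in both the halogen and its place on the ring, which leaves open whether the iodine itself or its place carries the step. From the compounds shown here alone, how a bromo or methyl group at the same place would read in this assay also remains open.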